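The source may hold more compounds than are shown below. What is called first, only, known or untested is meant among the compounds shown, and "the series" means these compounds.

Among the compounds with values here, in an ADME assay on the whole organism (strain FVB) for pharmacokinetics, with Mus musculus as the target, read by LC-MS, at a dose of 30 mg/kg by the oral route (a lower number here means less compound in the circulation, a higher number more compound in the circulation at the dose given), compound 1 `NCCOc1ccc([C@H]2CC[C@]3(CC2)OOC2(O3)C3CC4CC(C3)CC2C4)cc1` reaches 287 nM, while compound 2 `c1cc([C@H]2CC[C@]3(CC2)OOC2(O3)C3CC4CC(C3)CC2C4)ccc1OCCOC1CCNCC1` reaches 633 nM, the higher of the two numbers measured so far. Compound 3 `CC(C)(O)CNCCCOc1ccc([C@H]2CC[C@]3(CC2)OOC2(O3)C3CC4CC(C3)CC2C4)cc1` shares their core and differs from compound 2 at one place: ((2-hydroxy-2-methylpropyl)amino)methyl in place of (piperidin-4-yl)oxy on a saturated chain carbon, two bonds along the chain from an oxygen on an aromatic ring. In words, ((2-hydroxy-2-methylpropyl)amino)methyl stands in place of (piperidin-4-yl)oxy on a saturated chain carbon, two bonds along the chain from an oxygen on an aromatic ring. Within the data shown here, only one measured step bears on this site: a 2.2-fold higher number from compound 1 to compound 2 (0.34 log units; beyond the scatter), a modest step that swapped amino for (piperidin-4-yl)oxy. It involves a different exchange, so it offers only a rough guide to size and none to direction. A similarly modest change at most seems likely. The expected step is a 1.4-fold lower number from compound 2 to compound 3 (0.15 log units; within the scatter), so no change beyond the scatter is expected. For compound 3 the estimate is 450 nM, with an expected range from 170 nM to 1100 nM.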

Compound 3, maximal plasma concentration: 1210 nM
The estimate for compound 3 lay 2.7-fold (0.43 log units) below the measured number; the measured number lies above the stated range.
By their numbers in this assay, from the lowest: compound 1; then compounds 2 and 3 (each within the scatter of the next).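

In this assay, the open-chain ((2-hydroxy-2-methylpropyl)amino)methyl group gives a 1.9-fold higher number from compound 2 to compound 3 (0.28 log units; within the scatter), so at this position the ring of (piperidin-4-yl)oxy can give way to an open chain with no change beyond the scatter. Set against the plain amino group, the same open chain gives a 4.2-fold higher number from compound 1 to compound 3 (0.62 log units; beyond the scatter), which means that both larger groups seen here, with or without a ring, stand above amino, although two such groups are a very small sample. No measurement shown here explains these numbers. As far as these compounds go, the hydroxyl and the two methyl groups of the new group arrive together, so their separate contributions remain unknown. From the compounds shown here alone, whether a morpholine ring or a carboxylic acid at the end of this chain would give a similar number also remains open.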